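The compounds below may be only part of what the source reports. "The series", "measured", "known", "first", "only" and "open" are said of these compounds alone.

Of the compounds shown here, two built on the same core have been tested in a functional assay on the whole organism (strain Wistar) for inhibition, with Rattus norvegicus as the target, read by paw edema, with a stated time of 2 h, at a dose of 100 mg/kg; on this read-out higher numbers stand for more inhibition at the one dose given (going by the name of the read-out) and lower numbers for less inhibition. Compound 1, with the structure `COc1cc2c(cc1OC)C(CC(=O)Nc1cccc(Cl)c1)CC2`, gives 28% in this assay. Compound 2, with the structure `COc1cc2c(cc1OC)C(CC(=O)Nc1ccccc1C)CC2`, gives 18% in this assay. For the measured compounds named here, the one measured step between them, a number 10 percentage points lower from compound 1 to compound 2 (within the scatter), is within the scatter, so the two numbers cannot be told apart, and compound 2 stands with compound 1 in the same band of the readings.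

Compound 3, with the structure `COc1cc2c(cc1OC)C(CC(=O)Nc1cccc(C)c1)CC2`, has not yet been measured in this assay. Its difference from compound 2 is 3-methylphenyl in place of 2-methylphenyl on an amide-type nitrogen. Going by the values given here, no measured step bears directly on moving a methyl from one position of the phenyl to another; the only measured step, from compound 1 to compound 2, exchanges a different substituent and is itself within the scatter. For this reason no step beyond the scatter is expected in this assay, and the step of a number 4 percentage points higher from compound 2 to compound 3 (within the scatter) is estimated to be small. Compound 3 is therefore expected to give about 22% in this assay, with a likely range from 8% to 36%.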

Compound 3, a percentage reported as inhibition, in the whole organism at one dose (the size of the read-out at that dose, not a potency): 29%
Compound 3: the middle estimate sits 7 percentage points below what was measured, and the stated range covers the measured number.
By their numbers in this assay, from the lowest: compounds 2, 1 and 3 (each within the scatter of the next, the first and the last beyond it).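

In this assay, the change from 2-methylphenyl to 3-methylphenyl on the amide-type nitrogen gives a number 11 percentage points higher from compound 2 to compound 3 (beyond the scatter), a modest step and the only one shown that lies beyond the scatter. For the compounds shown here, the two compounds have the same atoms joined differently, so this step shows that where the methyl sits on the phenyl can register in this read-out, which the earlier pair could not show because its one step stayed within the scatter. Methyl in place of chloro on an aromatic carbon gives a number 1 percentage points higher from compound 1 to compound 3 (within the scatter), within the scatter, so compound 1 and compound 3 cannot be told apart, and no available measurement explains the effect of moving the methyl.

The compounds shown leave open whether a methoxy group, an amine or a carboxylic acid on the phenyl would read differently from the methyl and chloro groups, and how a phenyl with no substituent would compare. Going by these compounds, each number also comes from a single dose and a single stated time, so whether the step from 2-methylphenyl to 3-methylphenyl would hold under other conditions remains open.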